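The source may hold more compounds than are shown below. What is called first, only, known or untested is meant among the compounds shown, and "the series" means these compounds.

Compound 1 `CC1=CC[C@H](C(C)(C)NC(=S)N/N=C/c2ccccc2O)CC1` bears a 2-hydroxyphenyl on the carbon with a double bond to nitrogen. In a functional assay on PC-3 cells (Homo sapiens) for inhibition, read by sulforhodamine B assay, with a stated time of 48 h (on this read-out higher numbers stand for weaker inhibition of growth and lower numbers for stronger inhibition of growth), compound 1 gives < 40 nM, which is a limit of the assay and not a number. Compound 2 `CC1=CC[C@H](C(C)(C)NC(=S)N/N=C/c2ccc(F)cc2)CC1` has a 4-fluorophenyl at that position. In this assay compound 2 gives < 40 nM, again a limit. The step that the two limits leave unreadable from compound 1 to compound 2 is left unreadable by the two limits, both of which sit at the limit of < 40 nM in this assay, at which 2 of the 2 values shown sit. Compound 3 `CC1=CC[C@H](C(C)(C)NC(=S)N/N=C/c2ccccc2[N+](=O)[O-])CC1` differs from compound 1 by nitro in place of hydroxy on an aromatic carbon. Among the measured compounds shown here, no measured step touches a nitro group, and the only measured change on that ring, from compound 1 to compound 2, has no readable size. With compound 1 standing at < 40 nM, a limit, compound 3 is expected to stay near the same region, the step that the limit leaves unreadable from compound 1 to compound 3 expected to be small. Compound 3 is thus estimated at 30 nM, within 5 nM to 150 nM, in this assay.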

Compound 3, concentration for 50% growth inhibition: 1700 nM
For compound 3 the middle estimate is 57-fold (1.75 log units) below the measured one; the measured number lies above the stated range.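

In this assay, nitro in place of hydroxy on an aromatic carbon, ortho to a large group, gives an at least 42-fold higher number from compound 1 to compound 3 (1.62 log units; beyond the scatter), so this place on the ring does not tolerate every group. Among the compounds shown here, the earlier step, between two limits, cannot be read, and this is the first change on this ring with a readable size. That size is itself a bound and not an exact figure, as compound 1 stands at a limit of the assay: the limit of < 40 nM in this assay, at which 2 of the 3 values shown sit.

The compounds shown do not tell whether the step comes from the hydroxy leaving or from the nitro entering, and an amine, a methoxy group or a plain hydrogen at this place would separate the two. Going by these compounds, how nitro behaves elsewhere on the ring also stays open.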